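The source may report more compounds than this note shows. Statements on the series, on what has been measured and on what is new or still open speak of the compounds shown alone.

Compound 3 `C=CC(=O)c1ccc(CCC)cc1` carries a propyl chain on the aromatic ring and an unsubstituted vinyl group on the carbonyl carbon. In an assay on isolated protein for displacement of a labelled ligand from thyroid hormone receptor alpha (Homo sapiens), read by fluorescence polarization (on this read-out lower numbers stand for stronger inhibition and higher numbers for weaker inhibition), compound 3 reaches only a limit, > 100000 nM, which is a boundary of the measurement and not a number. Compound 3 therefore stands at the limit of > 100000 nM in this assay, at which 1 of the 3 values shown sits.

Two other compounds carry a heptyl chain instead. Compound 1 `C/C=C/C(=O)c1ccc(CCCCCCC)cc1` bears a prop-1-en-1-yl group on the carbonyl carbon, and compound 2 `C=C(C)C(=O)c1ccc(CCCCCCC)cc1` bears a 1-methylethenyl group there. In this assay compound 1 gives 18900 nM and compound 2 gives 52900 nM. Among the measured compounds shown here, the only measured step, a 2.8-fold higher number from compound 1 to compound 2 (0.45 log units; beyond the scatter), concerns the group on the carbonyl carbon, not the chain on the ring.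

Compound 4 `C=CC(=O)c1ccc(CCCCCCC)cc1` differs from compound 3 by butyl in place of hydrogen on a saturated chain carbon, three bonds along the chain from an aromatic carbon. For the measured compounds named here, no measured step covers this chain lengthening directly. What the data show is that compound 1 and compound 2, both with the heptyl chain, give measurable numbers, while compound 3, with the shorter chain, does not.

Compound 4 is therefore expected to move from the limit into the measurable range, a step estimated at an at least 4.0-fold lower number from compound 3 to compound 4 (0.60 log units; beyond the scatter). For compound 4 the estimated value is 25000 nM, within a range from 8000 nM to 90000 nM.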

Compound 4, half-maximal inhibitory concentration: 23000 nM
The estimate for compound 4 lay 1.1-fold (0.04 log units) above the measured number; the range from low to high includes it.
By their numbers in this assay, from the lowest: compounds 1 and 4 (each within the scatter of the next); then compound 2. At a limit, above all of these: compound 3.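

Compound 3 sits at a limit of the measurement, not at a number: the limit of > 100000 nM in this assay, at which 1 of the 4 values shown sits. In this assay, among the compounds shown here, the vinyl group now stays fixed while the chain changes, so the effect of chain length can be read directly for the first time: an at least 4.3-fold lower number from compound 3 to compound 4 (0.63 log units; beyond the scatter), with butyl in place of hydrogen on a saturated chain carbon, three bonds along the chain from an aromatic carbon. Among the heptyl compounds, the group on the carbonyl carbon can now be compared with vinyl: a 1.2-fold higher number from compound 1 to compound 4 (0.09 log units; within the scatter), so vinyl and prop-1-en-1-yl cannot be told apart here, whereas a 2.3-fold lower number from compound 2 to compound 4 (0.36 log units; beyond the scatter), so only the methyl on the double-bonded chain carbon bound to a carbonyl carbon separates from vinyl.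

The compounds shown leave open how the number runs with other chain lengths, such as a pentyl or a decyl chain. They also leave open what a chain carrying an amine or a carboxylic acid would give, and whether a saturated ethyl group in place of vinyl on the carbonyl carbon would still give a measurable number.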